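Methyl in Place of Nitro, Tested on a Second Core

The compounds below may be only part of what the source reports. "The series", "measured", "known", "first", "only" and "open" are said of these compounds alone.

Compound 1 `CC1=NN(C(=O)c2ccc([N+](=O)[O-])cc2)C(c2ccccc2O)C1` gives 50000 nM in a functional assay on MGC-803 cells (Homo sapiens) for cytotoxicity, read by MTT assay, with a stated time of 48 h; on this read-out lower numbers stand for stronger inhibition and higher numbers for weaker inhibition.
Compound 2 `CC1=NN(C(=O)c2ccc(C)cc2)C(c2ccccc2O)C1` gives 26300 nM in this assay.
Compound 3 `O=c1oc2ccccc2cc1C1=NN(S(=O)(=O)c2ccc([N+](=O)[O-])cc2)C(c2ccccc2)C1` gives 41200 nM in this assay.

Compound 2 differs from compound 1 by one change, (methyl in place of nitro on an aromatic carbon), and the step in this assay is a 1.9-fold lower number from compound 1 to compound 2 (0.28 log units; within the scatter). Compound 4 `Cc1ccc(S(=O)(=O)N2N=C(c3cc4ccccc4oc3=O)CC2c2ccccc2)cc1` carries the same change on a different core: methyl in place of nitro on an aromatic carbon. How the core of compound 3 differs from the core of compound 1 is not broken down here, so only the shared change can guide an expectation. Since the earlier step was a 1.9-fold lower number from compound 1 to compound 2 (0.28 log units; within the scatter), the step from compound 3 to compound 4 is expected to be similar, a 1.4-fold lower number from compound 3 to compound 4 (0.14 log units; within the scatter). Compound 4 is therefore estimated at 30000 nM in this assay, with a range from 12000 nM to 70000 nM.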

Compound 4, half-maximal inhibitory concentration: 50200 nM
The estimate for compound 4 lay 1.7-fold (0.22 log units) below the measured number; measured number inside the range.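

In this assay, putting methyl in place of nitro gives a 1.2-fold higher number from compound 3 to compound 4 (0.09 log units; within the scatter), so on this second core, too, the change stays within the usual scatter of repeated measurements. Set side by side, the two steps cannot be told apart: the same change on two cores in this assay, a 1.9-fold lower number (0.28 log units; within the scatter) from compound 1 to compound 2 and a 1.2-fold higher number (0.09 log units; within the scatter) from compound 3 to compound 4, 2.3-fold (0.36 log units) apart, within the scatter of two such steps. This shows that the change behaves alike on both cores as far as this assay can resolve, but it does not show that the change has a real effect on either core, and a small difference between the cores could still be hidden in the scatter.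

The compounds shown carry only nitro or methyl in this place. As far as these compounds go, whether an amine, a carboxylic acid or a chlorine atom there would move the number beyond the scatter remains open.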